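This account rests on a few compounds, and the source may have more. Where it says the series, first, only, none or still open, it means among the compounds named here.

Compound 3 `Cc1cc(-c2ccccc2)n(/C(N)=N/S(=O)(=O)c2cc(C)c(Cl)cc2SCc2ccc(Cl)cc2)n1` gives 108000 nM in a functional assay on MCF7 cells (Homo sapiens) for cytotoxicity, read by MTT assay, with a stated time of 72 h; on this read-out lower numbers stand for stronger inhibition and higher numbers for weaker inhibition; compound 2 `Cc1cc(S(=O)(=O)/N=C(\N)n2nccc2-c2ccccc2)c(SCc2cccc3ccccc23)cc1Cl` gives 58000 nM, within the scatter of that, while compound 1 `Cc1cc(S(=O)(=O)/N=C(\N)n2nccc2-c2ccccc2)c(SCc2ccc(C(F)(F)F)cc2)cc1Cl` gives 25000 nM, beyond the scatter below it. Compound 4 `Cc1cc(S(=O)(=O)/N=C(\N)n2nccc2-c2ccccc2)c(SCc2ccc(Cl)cc2)cc1Cl` differs from compound 3 by hydrogen in place of methyl on an aromatic carbon. Going by the values given here, no measured step touches this change: the only step on hand, a 2.3-fold higher number from compound 1 to compound 2 (0.37 log units; beyond the scatter), concerns the group on the saturated chain carbon bound to a sulfur and says nothing about the methyl. Compounds 1 and 2, which both lack the methyl, stay within the same broad band, so the expected step in this assay is small, at most a modest fall. For compound 4 the expected value is 55000 nM, in a range from 20000 nM to 150000 nM, which means an expected 2.0-fold lower number from compound 3 to compound 4 (0.29 log units; within the scatter).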

Compound 4, half-maximal inhibitory concentration: 75000 nM
For compound 4 the middle estimate is 1.4-fold (0.13 log units) below the measured one, within the range that was stated.
By their numbers in this assay, from the lowest: compound 1; then compounds 2, 4 and 3 (each within the scatter of the next).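

In this assay, hydrogen in place of methyl on this aromatic carbon gives a 1.4-fold lower number from compound 3 to compound 4 (0.16 log units; within the scatter), so the assay does not separate the two groups at this position. Going by these compounds alone, with the methyl gone, the step of a 1.3-fold higher number from compound 2 to compound 4 (0.11 log units; within the scatter) leaves 4-chlorophenyl and naphthalen-1-yl unseparated, while a 3.0-fold higher number from compound 1 to compound 4 (0.48 log units; beyond the scatter) is the only new step beyond the scatter. No evidence on hand bears on these steps. From the compounds shown here alone, whether an amine, a carboxylic acid or a longer chain on this aromatic carbon would stay in the same band remains open. So does what methyl does here alongside 4-(trifluoromethyl)phenyl.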